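Cyclohexyl Ether Variant of the Cyanopyridine Series

The source may report more compounds than this note shows. Statements on the series, on what has been measured and on what is new or still open speak of the compounds shown alone.

Measured so far:
compound 1 `N#Cc1cnc(NCc2cnccc2C(F)(F)F)cc1NC[C@H]1C[C@@H](O)C1` — 4200 nM
compound 2 `N#Cc1cnc(NCc2ccccc2C(F)(F)F)cc1N[C@H]1CC[C@@H](O)CC1` — 4500 nM
compound 3 `N#Cc1cnc(NCc2ccccc2C(F)(F)F)cc1N[C@H]1CC[C@H](O)CC1` — > 10000 nM

In an assay on isolated protein for inhibition of protein kinase C delta type (Homo sapiens), read by TR-FRET, with a stated time of 2 h (on this read-out higher numbers stand for weaker inhibition and lower numbers for stronger inhibition), compound 1 gives the lowest of the two numbers shown; compound 2 sits within the scatter of it, so no order between the two is claimed. Compound 3 reports only a limit in this assay. Going by the values given here, the single measured step, an at least 2.2-fold higher number from compound 2 to compound 3 (0.34 log units; beyond the scatter), rests on the fact that compounds 2 and 3 differ only in the configuration as drawn and on (the limit of > 10000 nM in this assay, at which 1 of the 3 values shown sits).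

Compound 4 `CO[C@H]1CC[C@@H](Nc2cc(NCc3cnccc3C(F)(F)F)ncc2C#N)CC1` differs from compound 1 by 4-methoxycyclohexyl in place of (3-hydroxycyclobutyl)methyl on a nitrogen on an aromatic ring. Among the compounds with values here, no measured step covers this change: the only step in hand, from compound 2 to compound 3, concerns configuration of a ring alcohol, not the exchange of a hydroxyl for a methoxy group or of the ring size. Compound 4 carries the pyridyl arm of compound 1 and a saturated ring drawn in the configuration of compound 2. Within the data shown here, with no step on the actual change, the expectation stays close to the measured neighbours, leaning weaker; compound 4 is expected at 6000 nM, between 2000 nM and 18000 nM, a step of a 1.4-fold higher number from compound 1 to compound 4 (0.15 log units; within the scatter).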

Compound 4, half-maximal inhibitory concentration: 5000 nM
Compound 4: middle estimate off by 1.2-fold (0.08 log units), on the high side; the range from low to high includes it.
By their numbers in this assay, from the lowest: compounds 1, 2 and 4 (each within the scatter of the next). At a limit, above all of these: compound 3.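

In this assay, 4-methoxycyclohexyl in place of (3-hydroxycyclobutyl)methyl on a nitrogen on an aromatic ring gives a 1.2-fold higher number from compound 1 to compound 4 (0.08 log units; within the scatter), so no order between the two compounds is claimed. This position therefore takes a six-membered ring in place of a four-membered one, and a group with 0 hydrogen-bond donors in place of one with 1, with no step beyond the scatter on this read-out. Nothing in hand gives a cause for this result.

Still open, going by these compounds, is how the ring size and the hydroxyl-to-methoxy exchange each count alone, since this pair changes both at once, and whether the opposite configuration of the 4-methoxycyclohexyl group would follow an at least 2.2-fold higher number from compound 2 to compound 3 (0.34 log units; beyond the scatter) as seen for the ring alcohol. Also open, on these data alone, is how a primary amine or a carboxylic acid in place of the methoxy group would read in this assay on the core of compound 4.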